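Estimating a Methyl Substituent's Effect on Cytotoxicity

The compounds below may be only part of what the source reports. "The series", "measured", "known", "first", "only" and "open" are said of these compounds alone.

Compound 1 `CC1=C(/C=C/C(=O)/C=C/c2ccccc2)C(C)(C)CCC1` is measured in a functional assay on HeLa cells (Homo sapiens) for cytotoxicity, read by sulforhodamine B assay, with a stated time of 48 h (a higher number here means a weaker inhibitor, a lower number a stronger inhibitor), where compound 1 gives 70200 nM. Among the three compounds measured so far it stands second highest: compound 2 `CC1=C(/C=C/C(=O)/C=C/c2ccc(Br)cc2)C(C)(C)CCC1` gives 88800 nM, and compound 3 `CC1=C(/C=C/C(=O)/C=C/c2ccccc2Cl)C(C)(C)CCC1` gives 21800 nM. The step of a 1.3-fold higher number from compound 1 to compound 2 (0.10 log units; within the scatter) lies within the scatter, whereas a 3.2-fold lower number from compound 1 to compound 3 (0.51 log units; beyond the scatter) and a 4.1-fold lower number from compound 2 to compound 3 (0.61 log units; beyond the scatter) are modest shifts toward a lower number.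

Compound 4 `CC1=C(/C=C/C(=O)/C=C/c2ccccc2C)C(C)(C)CCC1` differs from compound 1 by methyl in place of hydrogen on an aromatic carbon. The new group sits ortho to a large group on the shared core. For the measured compounds named here, of the measured steps, only a 3.2-fold lower number from compound 1 to compound 3 (0.51 log units; beyond the scatter) concerns a substituent at that place; no measured step involves a methyl, so the comparison is indirect. Because a 3.2-fold lower number from compound 1 to compound 3 (0.51 log units; beyond the scatter) was modest, a small to modest move toward a lower number is expected for compound 4, with wide uncertainty. Compound 4 is therefore estimated at 40000 nM, within 15000 nM to 100000 nM, which would correspond to an expected step of a 1.8-fold lower number from compound 1 to compound 4 (0.24 log units; within the scatter).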

Compound 4, half-maximal inhibitory concentration: > 100000 nM
Compound 4: only a limit was reported (the forecaster's own chance of this, stated with the estimate: 10%); middle value at least 2.5-fold (0.39 log units) away from the limit.
By their numbers in this assay, from the lowest: compound 3; then compounds 1 and 2 (each within the scatter of the next). At a limit, above all of these: compound 4.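

On an aromatic carbon ortho to a large group, the identity of the substituent proves decisive in this assay: methyl in place of chloro gives an at least 4.5-fold higher number from compound 3 to compound 4 (0.66 log units; beyond the scatter), so the lower number seen with chloro in compound 3 does not extend to methyl at the same place. Methyl in place of hydrogen gives an at least 1.4-fold higher number from compound 1 to compound 4 (0.15 log units; that floor lies within the scatter), and the comparison with the bromo compound gives an at least 1.1-fold higher number from compound 2 to compound 4 (0.05 log units; that floor lies within the scatter); both floors lie within the scatter, so neither step establishes a real separation. The figure for compound 4 is a limit and not a number: the limit of > 100000 nM in this assay, at which 1 of the 4 values shown sits.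

Going by these compounds, how far the true value of compound 4 lies beyond that limit remains open. Also unresolved is whether a methoxy group or an amine at this place would track chloro or methyl.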